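Hexahydroquinolinone series: ester to aryl at the ring carbon

A few compounds are considered here, and "the series" means these few. Any claim that something is new, unique, unknown or untested is made for them only; others in the source may bear on it.

Working notes on the shared core seen in compound 3 `CCOC(=O)C1=CC(c2ccccc2)C2=C(CC(C)(C)CC2=O)N1` and its relatives. In an assay on isolated protein for inhibition of glucose-6-phosphatase catalytic subunit 1 (Homo sapiens), read by inositol phosphate accumulation, with a stated time of 30 min, tested at 100 uM (on this read-out higher numbers stand for more inhibition at the one concentration tested (going by the name of the read-out) and lower numbers for less inhibition), compound 1 `O=C1CCCC2=C1C(c1ccc(F)cc1)C=C(c1ccccc1)N2` gives 21.9%. Compound 2 `CCOC(=O)C1=CC(c2ccc(Br)cc2)C2=C(CC(C)(C)CC2=O)N1` is reported as "not active" (no number reported). Within the data shown here, compound 3 stands at "not active" (no number reported) in this assay, so no single number is available for it, and its two closest relatives leave no measured step to build on. Compound 4 `Cc1ccc(C2=CC(c3ccccc3)C3=C(CC(C)(C)CC3=O)N2)cc1` differs from compound 3 by 4-methylphenyl in place of ethoxycarbonyl on a double-bonded ring carbon. With both ester-bearing compounds reported without a number and compound 1 carrying an aryl group at that ring carbon, a step upward is expected, though it may stay within the scatter. Compound 4 is expected to give 14% in this assay, with a range from 0% to 28%, and a real chance that only "not active" is reported again.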

Compound 4, a percentage reported as inhibition, at one concentration (the size of the read-out at that concentration, not a potency): "not active" (no number reported)
No number was reported for compound 4; there is nothing to compare the estimate with.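

Compound 3 and compound 4 are both reported as "not active" in this assay, so no step can be read between them, and no evidence bears on this result. The compounds shown leave open whether 4-methylphenyl in place of ethoxycarbonyl changes inhibition at all.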